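The source may report more compounds than this note shows. Statements on the series, on what has been measured and on what is new or still open speak of the compounds shown alone.

The series shares a core in which a sulfonamide links a uracil-like ring to a phenyl bearing a triazole, and the activity of interest is read in a functional assay on HepG2 cells (Homo sapiens) for antiproliferative activity, read by MTT assay, with a stated time of 24 h; a lower number here means a stronger inhibitor, a higher number a weaker inhibitor. Compound 1 `Cc1ccc(-n2cc(-c3ccccc3NS(=O)(=O)c3c[nH]c(=O)[nH]c3=O)nn2)cc1` gives 8350 nM in this assay. Within the data shown here, compound 2 `Cc1cccc(-n2cc(-c3ccc(NS(=O)(=O)c4c[nH]c(=O)[nH]c4=O)cc3)nn2)c1` does not give a number in this assay at all; its result is a limit of > 20000 nM, and the limit of > 20000 nM in this assay, at which 1 of the 2 values shown sits, describes where that limit sits among the values known so far. Compound 3 `O=c1[nH]cc(S(=O)(=O)Nc2ccc(-c3cn(-c4ccc(Cl)cc4)nn3)cc2)c(=O)[nH]1` differs from compound 2 only in the group carried on the aromatic nitrogen: 4-chlorophenyl in place of 3-methylphenyl on an aromatic nitrogen. Among the measured compounds shown here, no measured pair shows what such a swap does here, so the expected step from compound 2 to compound 3 in this assay is an at least 1.1-fold lower number from compound 2 to compound 3 (0.04 log units; that floor lies within the scatter), which is within the scatter and may again end at the limit. Compound 3 is therefore expected to give about 18000 nM in this assay, within the range 6000 nM to 50000 nM.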

Compound 3, half-maximal inhibitory concentration: 1980 nM
Compound 3: the middle estimate sits 9.1-fold (0.96 log units) above what was measured; measured number outside the range, below it.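

In this assay, the group on the aromatic nitrogen proves able to move the read-out: putting 4-chlorophenyl in place of 3-methylphenyl gives an at least 10-fold lower number from compound 2 to compound 3 (1.00 log units; beyond the scatter), a change beyond the scatter. Among these compounds, this is the first sign that this position responds to a swap, which compound 1 and compound 2 alone could not show. On these data alone, compound 2 has only a limit of the assay and not a number, so the step gives a floor and its full size stays unknown: the limit of > 20000 nM in this assay, at which 1 of the 3 values shown sits.

The swap changes both the group on the phenyl ring and where it stands, and the compounds shown do not separate these two changes. As far as these compounds go, whether an amine, a carboxylic acid or a longer chain on that phenyl ring would be tolerated also remains open.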